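Replacing the Amidine Carbon by a Carbonyl

The source may report more compounds than this note shows. Statements on the series, on what has been measured and on what is new or still open speak of the compounds shown alone.

Compound 1, `N=C(CS)NCc1ccccc1`: 83%
Compound 2, `N=C(CS)NC1CCCCC1`: 79%

Both measured compounds were tested in a functional assay on the whole organism (stomach, strain beagle) for inhibition, with Canis familiaris (Canis lupus familiaris) as the target, with a stated time of 2 h, at a dose of 8 mg/kg; on this read-out lower numbers stand for a weaker effect and higher numbers for a stronger effect at the one dose given. Compound 1 gives 83%, the highest of the two numbers shown. Compound 2 gives 79%, a value that lies within the scatter of the first, so the two cannot be ordered against each other; both show a strong effect at the single dose used.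

Compound 3, `O=C(CS)NCc1ccccc1`, has not yet been measured in this assay. It differs from compound 1 in one place: a group of 4 heavy atoms (2 carbon, 1 oxygen, 1 sulfur; no ring) in place of a group of 4 heavy atoms (2 carbon, 1 nitrogen, 1 sulfur; no ring), on an amine nitrogen. The group that enters carries one hydrogen-bond donor fewer than the group that leaves, and the carbon bearing the double bond now carries oxygen instead of nitrogen. Within the data shown here, no step between two measured compounds shows what such a change does here, so any expectation rests only on the standing of compound 1 and compound 2. The expected step of a number 38 percentage points lower from compound 1 to compound 3 (beyond the scatter) is a decrease beyond the scatter, with wide uncertainty. Compound 3 is estimated at 45%, with a range from 10% to 80%.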

Compound 3, a percentage reported as inhibition, in the whole organism at one dose (the size of the read-out at that dose, not a potency): 0%
Estimate against measurement, compound 3: 45 percentage points above; the whole stated range lies above it.
By their numbers in this assay, from the lowest: compound 3; then compounds 2 and 1 (each within the scatter of the next).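

Among these compounds, the swap on the amine nitrogen is the first change in this set to touch the group that compound 1 and compound 2 share, and in this assay it gives a number 83 percentage points lower from compound 1 to compound 3 (beyond the scatter). Compound 1 and compound 2 differ only in the other substituent on that nitrogen and both keep a strong effect, whereas the (sulfanylmethyl)carbonyl group leaves compound 3 at 0%, so in this pair the read-out depends far more on keeping the amidine nitrogen than the earlier values could show. Nothing available explains this loss, which could reflect the missing hydrogen-bond donor or some other difference between the two groups.

On these data alone, it remains open whether the same swap has a similar effect with the cyclohexyl group of compound 2, and whether a single dose and time point hide any weaker effect of compound 3. Also unresolved is how a thioamide, with sulfur in place of the carbonyl oxygen, an N-methyl amidine or a longer chain carrying the sulfanyl group would fare against compound 1.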